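The source may hold more compounds than are shown below. What is called first, only, known or untested is meant among the compounds shown, and "the series" means these compounds.

Of the compounds shown here, three built on one shared core have so far been tested in a functional assay on CHO cells for inhibition of Orexin/Hypocretin receptor type 1 (Homo sapiens), read by FLIPR and calcium flux; a higher number here means a weaker inhibitor, a lower number a stronger inhibitor. Compound 1, `CCN(CC)C(=O)CN(c1ccc(C)cc1)S(=O)(=O)c1ccc(OC)c(OC)c1`, gives > 10000 nM, which is a limit of the assay rather than a measured number. Compound 3, `CCN(CC)C(=O)CN(c1ccc(C)cc1)S(=O)(=O)c1cccc(F)c1`, likewise gives > 10000 nM, again a limit. Compound 2, `CCN(CC)C(=O)CN(c1cc(N(CC)CC)ccc1Cl)S(=O)(=O)c1ccc(OC)c(OC)c1`, gives > 10000 nM, also a limit. Among the compounds with values here, compound 2 therefore stands exactly where every value so far stands, at the limit of > 10000 nM in this assay, at which 3 of the 3 values shown sit, so none of the three can be ranked against another, and no step between two measured compounds exists to lean on.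

Compound 4, `CCN(CC)C(=O)CN(c1cc(C(C)C)ccc1Cl)S(=O)(=O)c1ccc(OC)c(OC)c1`, differs from compound 2 in a single place: isopropyl in place of diethylamino on an aromatic carbon. Within the data shown here, no measured step shows how such a change moves the half-maximal inhibitory concentration in this assay, and the expectation rests only on the three limits. With all three values sitting at the limit of > 10000 nM in this assay, at which 3 of the 3 values shown sit, no move beyond the scatter is expected in either direction, and the most likely outcome is that compound 4 again returns only a limit. Compound 4 is estimated at 15000 nM, within a range from 3000 nM to 60000 nM. In this assay the step that the limit leaves unreadable from compound 2 to compound 4 is expected to be none beyond the scatter.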

Compound 4, half-maximal inhibitory concentration: 888 nM
Beside the measured number, compound 4's estimate is 17-fold (1.23 log units) above it, and the stated range ends above it.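

In this assay, isopropyl in place of diethylamino on an aromatic carbon, para to a chloro group, gives an at least 11-fold lower number from compound 2 to compound 4 (1.05 log units; beyond the scatter), so the group at this one place separates a compound with a measurable half-maximal inhibitory concentration from one that stays at the limit of the assay. The change of the whole aromatic group, 2-chloro-5-isopropylphenyl in place of 4-methylphenyl on the sulfonamide nitrogen, gives an at least 11-fold lower number from compound 1 to compound 4 (1.05 log units; beyond the scatter), and both steps are minimum sizes, as each starts from a compound that has only a limit and the true gaps could be larger. Compound 4 is thus the first compound here that can anchor later comparisons, as the other three values remain limits: the limit of > 10000 nM in this assay, at which 3 of the 4 values shown sit.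

The compounds shown leave open whether isopropyl itself matters or whether removing diethylamino is enough, which a plain hydrogen, a methyl, a tert-butyl or a cyclopropyl at the same place could begin to separate. They also leave open how much the chloro group contributes, and whether a fluoro or a methyl there would give a similar value.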